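Swapping Chloro for a Methyl Triazole

The compounds below may be only part of what the source reports. "The series", "measured", "known", "first", "only" and "open" are said of these compounds alone.

In an ADME assay on microsomes from liver (Rattus norvegicus) for metabolic stability (a lower number here means slower removal, a higher number faster removal of the compound), compound 1 (`CNc1nc(NC2(C#N)CCCCC2)nc(-n2cncn2)n1`) gives 52 mL/min/kg and compound 2 (`CNc1nc(NC2(C#N)CCCCC2)nc(-n2ccnc2)n1`) gives 52 mL/min/kg as well, while compound 3 (`CNc1nc(Cl)nc(NC2(C#N)CCCCC2)n1`) stands highest of the three at 867 mL/min/kg on this scale. Compound 4 (`CNc1nc(NC2(C#N)CCCCC2)nc(-n2cnc(C)n2)n1`), not yet measured, carries 3-methyl-1H-1,2,4-triazol-1-yl in place of chloro on an aromatic carbon. Going by the values given here, two measured steps bear on this swap, run in the opposite direction. With chloro replacing 1H-1,2,4-triazol-1-yl there is a 17-fold higher number from compound 1 to compound 3 (1.22 log units; beyond the scatter) and with chloro replacing 1H-imidazol-1-yl there is a 17-fold higher number from compound 2 to compound 3 (1.22 log units; beyond the scatter) in each case a large step beyond the scatter. The two ring groups themselves differ little, with no change at the digits printed from compound 1 to compound 2 (within the scatter) as the measured step. Among the compounds with values here, no measured compound carries the added methyl, so its effect is unknown and the range stays wide. A large fall is therefore expected in this assay and the estimated step is a 13-fold lower number from compound 3 to compound 4 (1.13 log units; beyond the scatter) by this reasoning. For compound 4 the estimated clearance is 65 mL/min/kg with an expected range of 30 mL/min/kg to 140 mL/min/kg in this estimate.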

Compound 4, clearance: > 276 mL/min/kg
Compound 4 gave a limit, no number; the forecaster's own chance of this, stated with the estimate: 3%; middle value at least 4.2-fold (0.62 log units) from the limit.
By their numbers in this assay, from the lowest: compounds 1 and 2 (each within the scatter of the next); then compound 3.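

In this assay compound 4 gives a limit and not a number: the limit of > 276 mL/min/kg in this assay, at which 1 of the 4 values shown sits. Even so, the limit shows that this position is sensitive to a small change on the attached ring, since methyl in place of hydrogen gives an at least 5.3-fold higher number from compound 1 to compound 4 (0.72 log units; beyond the scatter), and the 3-methyl-1H-1,2,4-triazol-1-yl group in place of 1H-imidazol-1-yl gives an at least 5.3-fold higher number from compound 2 to compound 4 (0.72 log units; beyond the scatter), whereas the two unmethylated ring groups had shown no difference. As far as these compounds go, the step from the chloro compound cannot be read, so it stays unknown whether the methylated ring keeps any advantage over chloro.

The compounds shown leave open how far compound 4 lies beyond its limit. They also leave open whether an amine or a methoxy group at the same place on the triazole would behave like methyl or like hydrogen.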